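Acyl chain variation on a shared amide core

A few compounds are considered here, and "the series" means these few. Any claim that something is new, unique, unknown or untested is made for them only; others in the source may bear on it.

Measured compounds, values in a functional assay on HEK293 cells with transient receptor potential cation channel subfamily V member 1 (Homo sapiens) as the target; a higher number here means that more compound is needed for the effect, a lower number that less compound is needed:
compound 1 `COc1cc(CNC(=O)/C=C(\C)CCC=C(C)C)ccc1O`: 39.8 nM
compound 2 `COc1cc(CNC(=O)/C=C(C)/C=C/C=C(C)/C=C/C2=C(C)CCCC2(C)C)ccc1O`: 3.98 nM
compound 3 `CCCCCCCCC#CCCCCCCCC(=O)NCc1ccc(O)c(OC)c1`: 12.6 nM

All three share the same amide-bearing core and differ only in the acyl chain. Compound 3 stands second highest of the three numbers in this assay. Compound 1, with its smaller acyl group, lies higher than compound 3, beyond the scatter; compound 2 lies lower than compound 3, also beyond the scatter.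

Compound 4 `COc1cc(CNC(=O)CCCCCCCCC2CC2)ccc1O` is not yet measured. Relative to compound 3 the change is cyclopropylmethyl in place of dec-1-yn-1-yl on a saturated chain carbon, seven bonds along the chain from a carbonyl carbon. Going by the values given here, no step between two measured compounds follows a change of this kind, so any expectation rests on the spread among compounds 1 to 3 alone, where compound 1 with its smaller acyl chain gives 39.8 nM. A move toward a higher number is expected for compound 4, with a step of about a 2.4-fold higher number from compound 3 to compound 4 (0.38 log units; beyond the scatter), near the edge of the scatter. The estimate for compound 4 in this assay is 30 nM, with a range from 8 nM to 120 nM.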

Compound 4, half-maximal effective concentration: 3.16 nM
Compound 4: middle estimate off by 9.5-fold (0.98 log units), on the high side, outside the stated range (below it).
By their numbers in this assay, from the lowest: compounds 4 and 2 (each within the scatter of the next); then compound 3; then compound 1.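

In this assay, the dec-1-yn-1-yl group at this position is not required for a low number: cyclopropylmethyl in its place, on a saturated chain carbon seven bonds along the chain from a carbonyl carbon, gives a 4.0-fold lower number from compound 3 to compound 4 (0.60 log units; beyond the scatter). The acyl chain can therefore lose its triple bond and much of its length, and take on a three-membered ring, without a move to a higher number at this position. No measured evidence accounts for this step.

Going by these compounds alone, the single step changes chain length, triple bond and ring together, so it cannot show which of these accounts for the lower number. An isobutyl group or a cyclobutyl group at this place would help separate the ring from the shortening, while a terminal carboxylic acid or amine would test a different kind of chain end.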